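This account rests on a few compounds, and the source may have more. Where it says the series, first, only, none or still open, it means among the compounds named here.

Among the compounds with values here, in a functional assay on MDA-MB-231 cells (Homo sapiens) for antiproliferative activity, with a stated time of 4 days (on this read-out higher numbers stand for weaker inhibition and lower numbers for stronger inhibition), compound 1 (`COc1ccc(-c2[nH]c3ccc(C(C)C)cc3c2C=O)cc1`) gives 29 nM and compound 2 (`CCCCc1ccc2[nH]c(-c3ccc(OC)cc3)c(C=O)c2c1`) gives 6.7 nM, the lower of the two numbers so far. Compound 3 (`CCCCc1ccc2[nH]c(-c3ccc(CC)cc3)c(C=O)c2c1`) keeps the butyl of compound 2 and replaces its methoxy: ethyl in place of methoxy on an aromatic carbon. This is ethyl in place of methoxy on an aromatic carbon, para to a large group. Within the data shown here, the only measured step, a 4.3-fold lower number from compound 1 to compound 2 (0.64 log units; beyond the scatter), is butyl in place of isopropyl, a change elsewhere in the molecule, so it bears only indirectly on this one. Among the measured compounds shown here, both measured compounds carry the methoxy, so the data hold no direct precedent. A modest step of similar size toward a higher number in this assay is the working expectation, though a step within the scatter remains possible. The expected step is a 2.2-fold higher number from compound 2 to compound 3 (0.35 log units; beyond the scatter). Compound 3 is estimated at 15 nM, with an expected range from 4 nM to 60 nM.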

Compound 3, half-maximal inhibitory concentration: 27 nM
Compound 3: middle estimate off by 1.8-fold (0.26 log units), on the low side, and the stated range covers the measured number.
By their numbers in this assay, from the lowest: compound 2; then compounds 3 and 1 (each within the scatter of the next).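

With the butyl held fixed, ethyl in place of methoxy gives a 4.0-fold higher number from compound 2 to compound 3 (0.61 log units; beyond the scatter) in this assay. Within the data shown here, this is the first read on this place, on an aromatic carbon para to a large group: it does not tolerate every swap equally, and methoxy gives the lower number of this pair. The exchange leaves the heavy-atom count unchanged and removes the hydrogen-bond acceptor of the methoxy, but no measurement shown accounts for the step.

Still open, going by these compounds, is whether the oxygen itself matters, which ethoxy, hydroxyl or a chlorine at this place could help to separate. Also open, on these data alone, is whether the same step would appear with isopropyl in place of butyl, or with a longer chain at that other site.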